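The source may hold more compounds than are shown below. What is called first, only, known or untested is meant among the compounds shown, and "the series" means these compounds.

Measured in a functional assay on RKO cells (Homo sapiens) for cytotoxicity, read by resazurin assay, with a stated time of 72 h; on this read-out lower numbers stand for stronger inhibition and higher numbers for weaker inhibition:
Compound 1 `Cc1cn(-c2csc(Nc3ccc(Br)cc3)n2)c(C)n1`: 400 nM
Compound 2 `Cc1ccc(Nc2nc(-n3ccnc3C)cs2)cc1`: 450 nM

Compound 2 stands level with compound 1. Their two numbers lie within the usual scatter of repeated measurements, so neither can be ranked above the other. These two compounds differ in more than one place, so they do not isolate a single structural change.

Compound 3 `Cc1ccc(Nc2nc(-n3cc(C)nc3C)cs2)cc1` departs from compound 2 in one place only: methyl in place of hydrogen on an aromatic carbon. This puts a methyl in place of hydrogen on an aromatic carbon of the five-membered aromatic ring with 2 nitrogen. Among the measured compounds shown here, no measured pair shows this change alone. The nearest evidence is compound 1, at 400 nM, which already carries a methyl at that place and also differs elsewhere. Its number lies within the scatter of compound 2 at 450 nM. No step beyond the scatter is therefore expected in this assay, and neither direction is favoured. The estimate corresponds to a 1.1-fold lower number from compound 2 to compound 3 (0.03 log units; within the scatter), an expected step of small size. For compound 3 the estimated value is 420 nM, with an expected range from 170 nM to 1000 nM.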

Compound 3, half-maximal inhibitory concentration: 200 nM
Compound 3: the middle estimate sits 2.1-fold (0.32 log units) above what was measured; measured number inside the range.
By their numbers in this assay, from the lowest: compounds 3, 1 and 2 (each within the scatter of the next, the first and the last beyond it).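

In this assay, among the compounds shown here, the added methyl gives the first direct reading at this position, on an aromatic carbon of the five-membered aromatic ring with 2 nitrogen: a 2.3-fold lower number from compound 2 to compound 3 (0.35 log units; beyond the scatter). One extra carbon at this place is therefore enough to give a modest step beyond the scatter, which the comparison of compound 1 with compound 2 could not show, as those two differ in more than one place. The change of methyl in place of bromo on an aromatic carbon, at a different place, gives a 2.0-fold lower number from compound 1 to compound 3 (0.30 log units; within the scatter), so this pair does not separate the two groups, and nothing here explains either result.

From the compounds shown here alone, whether the lower number depends on methyl itself remains open, since an ethyl group, a chlorine atom or an amine on the same ring carbon could show whether other groups there behave alike. For the compounds shown here, it also remains open whether the added methyl gives a similar step when the other ring carries bromo, as only one single-place pair speaks for this change.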